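The compounds below may be only part of what the source reports. "The series", "measured", "known", "first", "only" and "open" are said of these compounds alone.

Measured in a functional assay on HT-29 cells (Homo sapiens) for inhibition, read by MTT assay, with a stated time of 48 h; on this read-out lower numbers stand for stronger inhibition and higher numbers for weaker inhibition:
compound 1 `COc1cc(-c2nnc(SCc3ccc(C)cc3)n2-c2ccc(N(C)C)cc2)cc(OC)c1OC`: 27500 nM
compound 2 `COc1ccc(C(=O)CSc2nnc(-c3cc(OC)c(OC)c(OC)c3)n2-c2ccc(N(C)C)cc2)cc1`: 64000 nM
compound 3 `COc1cc(-c2nnc(SCC(=O)c3ccc4ccccc4c3)n2-c2ccc(N(C)C)cc2)cc(OC)c1OC`: > 60000 nM

For compound 3, the entry > 60000 nM is a limit of the assay and not a number. Its standing in the series therefore rests on (the limit of > 60000 nM in this assay, at which 1 of the 3 values shown sits).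

Compound 4 `COc1ccc(NC(=O)CSc2nnc(-c3cc(OC)c(OC)c(OC)c3)n2-c2ccc(N(C)C)cc2)cc1` carries (4-methoxyphenyl)amino in place of naphthalen-2-yl on a carbonyl carbon.

Going by the values given here, three measured steps bear on this change. Two start from the 4-methylphenyl of compound 1 and both raise the number modestly: a 2.3-fold higher number from compound 1 to compound 2 (0.37 log units; beyond the scatter) and an at least 2.1-fold higher number from compound 1 to compound 3 (0.33 log units; beyond the scatter). Neither of the two carbonyl-bearing side chains measured so far improves on compound 1. Among the compounds with values here, the only measured change on that same carbonyl carbon is a step that the limit leaves unreadable from compound 2 to compound 3, so it gives no size to carry over. The closest anchor is compound 2 at 64000 nM, which shares the 4-methoxyphenyl group with compound 4. A value in the same high range is therefore expected, with wide uncertainty.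

The expected step is an at least 1.5-fold lower number from compound 3 to compound 4 (0.17 log units; that floor lies within the scatter), small and towards a lower number. For compound 4 the estimated value is 40000 nM, with an expected range from 14000 nM to 90000 nM.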

Compound 4, half-maximal inhibitory concentration: 51400 nM
The estimate for compound 4 lay 1.3-fold (0.11 log units) below the measured number; the range from low to high includes it.
By their numbers in this assay, from the lowest: compounds 1, 4 and 2 (each within the scatter of the next, the first and the last beyond it).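

In this assay, (4-methoxyphenyl)amino on the carbonyl carbon gives a 1.2-fold lower number from compound 2 to compound 4 (0.10 log units; within the scatter), so the ketone of compound 2 and the amide of compound 4 cannot be told apart here, while a 1.9-fold higher number from compound 1 to compound 4 (0.27 log units; within the scatter) makes compound 4 the first carbonyl-bearing side chain that stays within the scatter of the 4-methylphenyl of compound 1. The replacement of naphthalen-2-yl gives an at least 1.1-fold lower number from compound 3 to compound 4 (0.06 log units; that floor lies within the scatter), which does not separate these two groups. The entry for compound 3 is a limit of the assay and not a number, and this step therefore reads only as a floor: the limit of > 60000 nM in this assay, at which 1 of the 4 values shown sits.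

Every compound shown stays in a high range, with compound 1 at 27500 nM, so it remains open whether any group on this side chain can move the number well away from that level. A carboxylic acid on the carbonyl carbon, a saturated amine such as morpholine in place of the (4-methoxyphenyl)amino, or a methyl on the amide nitrogen would test whether the amide hydrogen and the aromatic ring matter at this position.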